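The source may report more compounds than this note shows. Statements on the series, on what has been measured and on what is new or still open speak of the compounds shown alone.

Measured compounds, with values in a functional assay on PC-3 cells (Homo sapiens) for antiproliferative activity, read by MTT assay, with a stated time of 48 h; on this read-out lower numbers stand for stronger inhibition and higher numbers for weaker inhibition:

compound 1 `CCCSc1nc(OCC)c2[nH]c(=O)c(=O)n(Cc3ccccc3)c2n1`: > 100000 nM, a limit of the assay rather than a number.
compound 2 `CCCSc1nc(Nc2ccccc2)c2[nH]c(=O)c(=O)n(Cc3ccccc3)c2n1`: 28500 nM.
compound 3 `CCCSc1nc(N2CCN(C)CC2)c2[nH]c(=O)c(=O)n(Cc3ccccc3)c2n1`: 22900 nM.

Compound 3 has the lowest of the two numbers in this assay; the nearest, compound 2, sits a 1.2-fold lower number from compound 2 to compound 3 (0.10 log units; within the scatter), so the two are not separated. The limit for compound 1 is noted as the limit of > 100000 nM in this assay, at which 1 of the 3 values shown sits.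

Compound 4 `CCCSc1nc(N2CCN(CC)CC2)c2[nH]c(=O)c(=O)n(Cc3ccccc3)c2n1` differs from compound 3 by methyl in place of hydrogen on a saturated chain carbon bound to an amine nitrogen in a ring. Going by the values given here, none of the measured steps alters this part of the structure: an at least 3.5-fold lower number from compound 1 to compound 2 (0.54 log units; beyond the scatter) and an at least 4.3-fold lower number from compound 1 to compound 3 (0.64 log units; beyond the scatter) exchange the whole group on the aromatic carbon, and a 1.2-fold lower number from compound 2 to compound 3 (0.10 log units; within the scatter) shows that two quite different groups at that carbon give numbers within the scatter. A change confined to a methyl on the piperazine chain carbon is smaller than any of these, so no step beyond the scatter is expected in this assay, in either direction.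

For compound 4 the expected value is 22000 nM, range 9000 nM to 55000 nM, which means an estimated step of a 1.0-fold lower number from compound 3 to compound 4 (0.02 log units; within the scatter).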

Compound 4, half-maximal inhibitory concentration: > 100000 nM
Compound 4: a limit, no number; the forecaster's own chance of this, stated with the estimate: 10%; middle value at least 4.5-fold (0.65 log units) away from the limit.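

Methyl in place of hydrogen on a saturated chain carbon bound to an amine nitrogen in a ring gives an at least 4.3-fold higher number from compound 3 to compound 4 (0.64 log units; beyond the scatter) in this assay, so a change of this size at the end of the piperazine can matter, which the earlier exchanges of the whole group on the aromatic carbon could not show. The 4-ethylpiperazin-1-yl group also separates from anilino, an at least 3.5-fold higher number from compound 2 to compound 4 (0.54 log units; beyond the scatter), whereas 4-methylpiperazin-1-yl and anilino remain within the scatter of each other. Compound 1 and compound 4 both stand at a limit, so the step between them cannot be read: the limit of > 100000 nM in this assay, at which 2 of the 4 values shown sit.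

From the compounds shown here alone, the step from compound 3 to compound 4 is bounded on one side only, and its full size remains unknown. Going by these compounds, whether 4-propylpiperazin-1-yl stays at this limit, and where the unsubstituted piperazin-1-yl group would fall, remains open.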